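The source may hold more compounds than are shown below. What is called first, only, known or untested is meant among the compounds shown, and "the series" means these compounds.

Measured in an ADME assay on a cell-free system (plasma, Homo sapiens); on this read-out higher numbers stand for a larger free fraction and lower numbers for a smaller free fraction:
- compound 1 `CC(=O)Nc1cc(-c2cnc(N(C)C(=O)c3c(F)cccc3Cl)c(N3CC4CC4C3)c2)n(C(C)C)n1`: 0.056
- compound 2 `CN(C(=O)c1c(F)cccc1Cl)c1ccc(-c2cc(C(N)=O)ccc2Cl)cc1OCC(F)(F)F`: 0.003
- compound 3 `CC(=O)Nc1cc(-c2ccc(N(C)C(=O)c3c(F)cccc3Cl)c(OCC(C)C)c2)n(C(C)C)n1`: 0.003

Level with compound 3, compound 2 shares the lowest value of the three. Compound 1 lies beyond the scatter above both.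

Compound 4 `CC(C)n1nc(C(N)=O)cc1-c1ccc(N(C)C(=O)c2c(F)cccc2Cl)c(OCC(F)(F)F)c1` carries 3-carbamoyl-1-isopropyl-1H-pyrazol-5-yl in place of 5-carbamoyl-2-chlorophenyl on an aromatic carbon. For the measured compounds named here, no measured pair isolates this change. Compound 1 and compound 3 each carry a five-membered aromatic ring with 2 hetero atoms, yet their values stand far apart, so they give no firm guide. A small rise, close to the scatter, is expected: the estimated change is a 2.7-fold higher number from compound 2 to compound 4 (0.43 log units; beyond the scatter). For compound 4 the estimated value is 0.008, with an expected range of 0.003 to 0.025.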

Compound 4, unbound fraction in the plasma assay: 0.059
Beside the measured number, compound 4's estimate is 7.4-fold (0.87 log units) below it; the whole stated range lies below it.
By their numbers in the plasma assay, from the lowest: compounds 2 and 3 (each within the scatter of the next); then compounds 1 and 4 (each within the scatter of the next).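

In the plasma assay, 3-carbamoyl-1-isopropyl-1H-pyrazol-5-yl in place of 5-carbamoyl-2-chlorophenyl gives a 20-fold higher number from compound 2 to compound 4 (1.29 log units; beyond the scatter), so the group at this position, meta to the 2,2,2-trifluoroethoxy group, can move the free fraction strongly. The earlier compounds shown here differ in more than one place and could not tie any change to this position. In a physicochemical assay for solubility, measured as kinetic solubility (a lower number here means a less soluble compound, a higher number a more soluble compound), compound 2 gives 0.3 ug/mL and compound 4 gives 32 ug/mL. The same replacement also raises solubility: the measured solubility of compound 2, 0.3 ug/mL, and of compound 4, 32 ug/mL, a 110-fold higher number (2.03 log units; beyond the scatter)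

The step changes the ring, adds the isopropyl group and removes the chlorine together, so no single part can be credited with the rise. As far as these compounds go, whether a carboxylic acid in place of the carbamoyl group would keep the gain also remains open.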